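Chain extension at the ((iodomethyl)carbonyl)amino end: working notes

This account rests on a few compounds, and the source may have more. Where it says the series, first, only, none or still open, it means among the compounds named here.

Compound 3 `Nc1ncnc2c1nc(NCCCCCCNC(=O)CI)n2[C@@H]1O[C@H](COP(=O)(O)OP(=O)(O)OP(=O)(O)O)[C@@H](O)[C@H]1O` and compound 1 `Nc1ncnc2c1nc(NCCCCCCCCNC(=O)CI)n2[C@@H]1O[C@H](COP(=O)(O)OP(=O)(O)OP(=O)(O)O)[C@@H](O)[C@H]1O` share a core. In an assay on isolated protein for inhibition of hexokinase-3 (Rattus norvegicus), with a stated time of 6 h, tested at 10 mM (on this read-out higher numbers stand for more inhibition at the one concentration tested (going by the name of the read-out) and lower numbers for less inhibition), compound 3 gives 0%, and compound 1 gives 0%. The change between them is 2-(((iodomethyl)carbonyl)amino)ethyl in place of ((iodomethyl)carbonyl)amino on a saturated chain carbon, six bonds along the chain from a nitrogen on an aromatic ring, and the step of no change at the digits printed from compound 3 to compound 1 (within the scatter) is within the scatter. Compound 2 `CN(CCCCN(C)c1ncnc2c1ncn2[C@@H]1O[C@H](COP(=O)(O)OP(=O)(O)OP(=O)(O)O)[C@@H](O)[C@H]1O)C(=O)CCCNC(=O)CI` rests on a different core; the difference between the two cores is not broken down here. In this assay compound 2 gives 0%, level with compounds 1 and 3. Compound 4 `CN(CCCCN(C)c1ncnc2c1ncn2[C@@H]1O[C@H](COP(=O)(O)OP(=O)(O)OP(=O)(O)O)[C@@H](O)[C@H]1O)C(=O)CCCCCNC(=O)CI` is not yet measured and differs from compound 2 by 2-(((iodomethyl)carbonyl)amino)ethyl in place of ((iodomethyl)carbonyl)amino on a saturated chain carbon, three bonds along the chain from a carbonyl carbon. This is the same kind of change as from compound 3 to compound 1, though the place differs: there six bonds along the chain from a nitrogen on an aromatic ring, here three bonds along the chain from a carbonyl carbon. Compound 4 is expected to give 0% in this assay, between -5% and 8%. The expected step of no change at the digits printed from compound 2 to compound 4 (within the scatter) rests on the earlier step of no change at the digits printed from compound 3 to compound 1 (within the scatter), which stayed within the scatter, and on compound 2 giving 0%.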

Compound 4, a percentage reported as inhibition, at one concentration (the size of the read-out at that concentration, not a potency): 0%
Compound 4: middle estimate and measured number agree at the digits printed, within the range that was stated.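

In this assay, 2-(((iodomethyl)carbonyl)amino)ethyl in place of ((iodomethyl)carbonyl)amino on the core of compound 2 shows no change at the digits printed from compound 2 to compound 4 (within the scatter), and the step on the other core reads alike: the same change on two cores in this assay, no change at the digits printed (within the scatter) from compound 3 to compound 1 and no change at the digits printed (within the scatter) from compound 2 to compound 4, 0 percentage points apart, within the scatter of two such steps. The change therefore carries from one core to the other without a visible step in this series, but the agreement is between two null steps, with all four compounds level. It does not show that the change would carry the same way on a compound with measurable inhibition.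

Open, going by these compounds, is whether a longer chain on either core would give any inhibition in this assay. Also open, on these data alone, is whether an amine or a carboxylic acid at the chain end in place of ((iodomethyl)carbonyl)amino would do so.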